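The compounds below may be only part of what the source reports. "The series", "measured", "known", "first", "only" and "open" are said of these compounds alone.

Three compounds share one core and differ only in the group attached to the carbonyl carbon. Compound 1 `CCCCCCCCNC(=O)[C@@H](NC(=O)c1ccco1)[C@@H](C)O` carries a furan-2-yl there, compound 2 `CCCCCCCCNC(=O)[C@@H](NC(=O)c1cc2ccccc2o1)[C@@H](C)O` a 1-benzofuran-2-yl, and compound 3 `CCCCCCCCNC(=O)[C@@H](NC(=O)/C=C/c1ccccc1)[C@@H](C)O` a 2-phenylethenyl. In a functional assay on A-431 cells (Homo sapiens) for cytotoxicity, read by MTT assay, with a stated time of 48 h (a lower number here means a stronger inhibitor, a higher number a weaker inhibitor), compound 1 gives 64500 nM, compound 2 gives 52700 nM, and compound 3 gives 36000 nM. Compound 1 has the highest number of the three, but the steps of a 1.2-fold lower number from compound 1 to compound 2 (0.09 log units; within the scatter) and a 1.8-fold lower number from compound 1 to compound 3 (0.25 log units; within the scatter) both stay within the scatter, as does a 1.5-fold lower number from compound 2 to compound 3 (0.17 log units; within the scatter), so the three stand level.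

Compound 4 `CCCCCCCCCCCCCCCCCCNC(=O)[C@@H](NC(=O)c1ccco1)[C@@H](C)O` keeps the furan-2-yl of compound 1 and changes only the chain on the other amide: decyl in place of hydrogen on a saturated chain carbon, eight bonds along the chain from an amide-type nitrogen. Among the compounds with values here, none of the measured steps touches that chain; every one of them alters the group on the carbonyl carbon. Within the data shown here, there is therefore no measured step to lean on, and the expectation for compound 4 in this assay rests on compound 1 alone, with a wide range. The step of a 1.8-fold lower number from compound 1 to compound 4 (0.27 log units; within the scatter) is an estimate, and compound 4 is expected to give about 35000 nM, most likely between 8000 nM and 120000 nM.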

Compound 4, half-maximal inhibitory concentration: 19900 nM
Beside the measured number, compound 4's estimate is 1.8-fold (0.25 log units) above it, within the range that was stated.
By their numbers in this assay, from the lowest: compounds 4, 3, 2 and 1 (each within the scatter of the next, the first and the last beyond it).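

The earlier compounds shown here changed only the group on the carbonyl carbon, and in this assay none of those changes moved the number beyond the scatter. Decyl in place of hydrogen on a saturated chain carbon, eight bonds along the chain from an amide-type nitrogen, gives a 3.2-fold lower number from compound 1 to compound 4 (0.51 log units; beyond the scatter) and so makes the chain on the other amide the first place in this set where a change clears the scatter, though only modestly. No measurement shown here explains this step.

With only two chain lengths shown, it remains open whether a still longer chain would continue in the same direction. Also open, going by these compounds, are whether the step would hold with the 1-benzofuran-2-yl of compound 2 or the 2-phenylethenyl of compound 3, and what an amine or a carboxylic acid on that chain would do.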